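The source may hold more compounds than are shown below. What is called first, only, known or untested is meant among the compounds shown, and "the series" means these compounds.

Of the compounds shown here, two have so far been measured in an assay on cells for inhibition of cytochrome P450 11B2, mitochondrial (Homo sapiens), read by HTRF, with stated times of 1 h and 3 h; a higher number here means a weaker inhibitor, a lower number a stronger inhibitor. Compound 1 `CC(O)(c1cncc(-n2ncc3cc(F)ccc32)c1)C(F)(F)F` gives 2 nM there, while compound 2 `CC(C)(O)c1cncc(-n2ncc3ccccc32)c1` gives 15 nM, the higher of the two numbers, and the gap between them lies beyond the usual scatter. Compound 3 `Cc1nn(-c2cncc(C(C)(C)O)c2)c2ccccc12` differs from compound 2 only by methyl in place of hydrogen on an aromatic carbon. For the measured compounds named here, no measured pair shows this change, so the step of a 1.5-fold lower number from compound 2 to compound 3 (0.18 log units; within the scatter) is expected to be small, within the scatter or a modest gain. Compound 3 is therefore estimated at 10 nM, with a range from 3 nM to 40 nM.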

Compound 3, half-maximal inhibitory concentration: 33.5 nM
Compound 3: the middle estimate sits 3.4-fold (0.53 log units) below what was measured, within the range that was stated.
By their numbers in this assay, from the lowest: compound 1; then compound 2; then compound 3.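

In this assay, methyl in place of hydrogen on an aromatic carbon of the five-membered aromatic ring gives a 2.2-fold higher number from compound 2 to compound 3 (0.35 log units; beyond the scatter) as a modest step. For the compounds shown here, this is the first change in a single place, and it shows that one added carbon at this position weakens inhibition rather than leaving it unchanged. Nothing at hand accounts for this step. On these data alone, whether ethyl, an amine or a nitrile at this position would behave like methyl stays open. So does whether the same step would appear on the core of compound 1.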